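The source may report more compounds than this note shows. Statements on the series, on what has been measured and on what is new or still open speak of the compounds shown alone.

Measured compounds:
compound 1 `Cc1cc(S(=O)(=O)/N=C(\N)n2nccc2-c2ccccc2)c(SCc2ccccc2Cl)cc1Cl`, 19000 nM in a functional assay on HeLa cells (Homo sapiens) for cytotoxicity, read by MTT assay, with a stated time of 72 h; a higher number here means a weaker inhibitor, a lower number a stronger inhibitor
compound 2 `Cc1cc(S(=O)(=O)/N=C(\N)n2nccc2-c2ccccc2)c(SCc2ccc(C(F)(F)F)cc2)cc1Cl`, 17000 nM in this assay
compound 3 `Cc1cc(-c2ccccc2)n(/C(N)=N/S(=O)(=O)c2cc(C)c(Cl)cc2SCc2ccccc2Cl)n1`, 270000 nM in this assay

Compound 3 gives the highest number of the three, so it is the weakest inhibitor here; the nearest is compound 1, and the gap between them, a 14-fold higher number from compound 1 to compound 3 (1.15 log units; beyond the scatter), lies well beyond the scatter, with compound 2 further still. That step from compound 1 to compound 3 is a methyl in place of hydrogen on an aromatic carbon, and it is large.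

Compound 4 `Cc1ccc(CSc2cc(Cl)c(C)cc2S(=O)(=O)/N=C(\N)n2nc(C)cc2-c2ccccc2)cc1` differs from compound 3 at a different position: 4-methylphenyl in place of 2-chlorophenyl on a saturated chain carbon bound to a sulfur. For the measured compounds named here, the one measured step that touches the same position is the change from compound 1 to compound 2, a 1.1-fold lower number from compound 1 to compound 2 (0.05 log units; within the scatter), where a different six-membered ring was swapped in at the same saturated chain carbon bound to a sulfur and the number barely moved. Going by the values given here, only one such comparison exists, so the expectation rests on it alone, but it points to no step beyond the scatter.

Compound 4 is therefore expected to give about 270000 nM, with a plausible range of 120000 nM to 600000 nM, an estimated step of no change at the digits printed from compound 3 to compound 4 (within the scatter).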

Compound 4, half-maximal inhibitory concentration: 62000 nM
Beside the measured number, compound 4's estimate is 4.4-fold (0.64 log units) above it, outside the stated range (below it).
By their numbers in this assay, from the lowest: compounds 2 and 1 (each within the scatter of the next); then compound 4; then compound 3.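

This position is not silent: the swap of 2-chlorophenyl for 4-methylphenyl on the saturated chain carbon bound to a sulfur gives a 4.4-fold lower number from compound 3 to compound 4 (0.64 log units; beyond the scatter) in this assay, a modest step beyond the scatter, whereas the earlier swap at the same place, a 1.1-fold lower number from compound 1 to compound 2 (0.05 log units; within the scatter), stayed within it. So a change at this carbon's ring can move the number, at least in the setting of compound 3, which carries the extra methyl on an aromatic carbon that compound 1 lacks. The two swaps differ both in the groups involved and in that setting, and no measurement here explains the difference between them.

Going by these compounds, it remains open whether 4-methylphenyl would have the same effect on the core of compound 1, and whether 4-(trifluoromethyl)phenyl would shift the number on the core of compound 3. Also open, on these data alone, is how this position would respond to a group such as 4-methoxyphenyl or cyclohexyl, or to a longer chain between the sulfur and the ring.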